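Aryl urea series: replacing the fluorophenyl on the urea nitrogen

The compounds below may be only part of what the source reports. "The series", "measured", "known", "first", "only" and "open" are said of these compounds alone.

Compound 3 `O=C(Nc1ccccc1F)N[C@H]1CC[C@H](Oc2ccc(F)cc2)CC1` gives 17500 nM in a functional assay on CRL2813 cells (Homo sapiens) for cytotoxicity, read by sulforhodamine B assay, with a stated time of 5 days; on this read-out higher numbers stand for weaker inhibition and lower numbers for stronger inhibition. Compound 1 `O=C(Nc1ccc(I)cc1)N[C@H]1CC[C@H](Oc2ccc(F)cc2)CC1` gives 10200 nM in this assay. For compound 2 `COc1ccccc1NC(=O)N[C@H]1CC[C@H](Oc2ccc(F)cc2)CC1` the read-out of this assay is a limit, > 20000 nM. Compound 3 thus holds the higher of the two numbers shown, with compound 1 its nearest neighbour, and the gap between them is small: a 1.7-fold higher number from compound 1 to compound 3 (0.23 log units; within the scatter). The remaining measured steps are an at least 1.9-fold higher number from compound 1 to compound 2 (0.29 log units; that floor lies within the scatter) and an at least 1.1-fold lower number from compound 2 to compound 3 (0.05 log units; that floor lies within the scatter), both running into (the limit of > 20000 nM in this assay, at which 1 of the 3 values shown sits), so none of the three aryl exchanges on the urea nitrogen has moved the number beyond the scatter.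

Compound 4 `CSc1cccc(NC(=O)N[C@H]2CC[C@H](Oc3ccc(F)cc3)CC2)c1` differs from compound 3 by 3-(methylsulfanyl)phenyl in place of 2-fluorophenyl on an amide-type nitrogen. Among the measured compounds shown here, the steps that bear on this change are the same three aryl exchanges on the same nitrogen, all of them flat within the scatter. On that basis no step beyond the scatter is expected in this assay, with a real chance that only a limit is returned given how weak the series is. The step expected is a 1.1-fold lower number from compound 3 to compound 4 (0.04 log units; within the scatter). Compound 4 is therefore estimated at 16000 nM, with a range from 6000 nM to 40000 nM.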

Compound 4, half-maximal inhibitory concentration: 11100 nM
Estimate against measurement, compound 4: 1.4-fold (0.16 log units) above, within the range that was stated.
By their numbers in this assay, from the lowest: compounds 1, 4 and 3 (each within the scatter of the next). At a limit, above all of these: compound 2.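

Position notes: the 3-(methylsulfanyl)phenyl group brings sulfur and a hydrogen-bond acceptor to the amide-type nitrogen, yet in this assay it stays within the scatter of both 2-fluorophenyl (a 1.6-fold lower number from compound 3 to compound 4 (0.20 log units; within the scatter)) and 4-iodophenyl (a 1.1-fold higher number from compound 1 to compound 4 (0.04 log units; within the scatter)). The flat response seen so far therefore extends to an aryl group that carries a sulfur-linked substituent, and compounds 1, 3 and 4 cannot be ranked on these numbers. From the compounds shown here alone, compound 2 remains a limit, > 20000 nM, so the comparison gives only a floor that does not separate the pair (an at least 1.8-fold lower number from compound 2 to compound 4 (0.25 log units; that floor lies within the scatter)), and its true distance from the other compounds stays unknown: the limit of > 20000 nM in this assay, at which 1 of the 4 values shown sits.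

Still open, going by these compounds, is whether any group on this nitrogen can move the number beyond the scatter in either direction, for example an aryl group bearing an amine or a carboxylic acid, or a longer alkyl chain in place of the aryl group. Also open, on these data alone, is whether this flat response depends on the rest of the shared core, which is the same in all four compounds.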